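This account rests on a few compounds, and the source may have more. Where it says the series, first, only, none or still open, it means among the compounds named here.

Working notes on a series built on a shared core, followed in an ADME assay on BJ cells (Homo sapiens) for cytotoxicity, with a stated time of 72 h; a higher number here means that more compound is needed for the effect, a lower number that less compound is needed. Compound 1 `Cc1cc(NC(=O)Nc2ccc(Cl)cc2)c2ccccc2n1` carries a chloro group on an aromatic carbon of the outer ring. In this assay compound 1 returns only a limit, > 25000 nM. Compound 2 `Cc1cc(NC(=O)Nc2ccc(C(N)=O)cc2)c2ccccc2n1` carries carbamoyl in place of chloro on an aromatic carbon. In this assay compound 2 likewise returns only a limit, > 25000 nM. The step that the two limits leave unreadable from compound 1 to compound 2 cannot be read in size or direction because the limit of > 25000 nM in this assay, at which 2 of the 2 values shown sit, holds both values. Compound 2 therefore stands at the limit of this assay, and nothing in the numbers separates it from compound 1.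

Compound 3 `Cc1cc(NC(=O)Nc2ccc(SC(F)(F)F)cc2)c2ccccc2n1` is the next step from compound 2: (trifluoromethyl)sulfanyl in place of carbamoyl on an aromatic carbon. Among the compounds with values here, only the step from compound 1 to compound 2 bears on it, and that step gives no readable size, so no step beyond the usual scatter can be expected in this assay in either direction from what is known. The estimate for compound 3 is 25000 nM, with a range of 8000 nM to 80000 nM, and the result may again come back only as a limit. The step this estimate implies is a number no higher from compound 2 to compound 3 (the limit leaves the size open), expected to lie within the scatter.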

Compound 3, half-maximal effective concentration in the BJ assay: > 25000 nM
Compound 3: a limit, no number; the forecaster's own chance of this, stated with the estimate: 60%; the middle value lies on the limit itself.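

In the BJ assay no new step can be read among compound 1, compound 2 and compound 3, since all three return only a limit: the limit of > 25000 nM in the BJ assay, at which 3 of the 3 values shown sit. In a physicochemical assay for solubility, at pH 7.4 (a lower number here means a less soluble compound, a higher number a more soluble compound), compound 2 gives 900 nM and compound 3 gives 200 nM (a 4.5-fold lower number from compound 2 to compound 3 (0.65 log units; beyond the scatter)). The compounds shown leave open whether any group at this place on the shared core gives a readable value in the BJ assay.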